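Ortho substituent swap on the shared core

The source may report more compounds than this note shows. Statements on the series, on what has been measured and on what is new or still open speak of the compounds shown alone.

Three compounds share the core shown for compound 1 `COC(=O)C1=C(C)N=C(C)/C(=C(\O)OC)C1c1ccccc1C(F)(F)F` and differ only in the aromatic ring attached to it. In a functional assay (muscle tissue) with Cavia porcellus as the target (on this read-out lower numbers stand for an effect already at smaller amounts and higher numbers for an effect only at larger amounts of compound), compound 1 gives 1.51 nM, the lowest of the three numbers. Compound 2 `COC(=O)C1=C(C)N=C(C)/C(=C(\O)OC)C1c1cc([N+](=O)[O-])ccc1Cl` gives 30.2 nM in this assay, and compound 3 `COC(=O)C1=C(C)N=C(C)/C(=C(\O)OC)C1c1cccc(C(F)(F)F)c1` gives 74.1 nM; both steps from compound 1 lie beyond the scatter.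

Compound 4 `C=Cc1ccccc1C1C(C(=O)OC)=C(C)N=C(C)/C1=C(\O)OC` has not yet been measured. Against compound 1 the change is vinyl in place of trifluoromethyl on an aromatic carbon. Among the measured compounds shown here, no measured pair shows this change, so its size is not known from the data at hand; the new group sits on the same aromatic carbon as the group it replaces, while compound 3 carries the trifluoromethyl elsewhere and is the only guide to what a different placement does. A moderate loss is expected, with the step estimated as a 3.3-fold higher number from compound 1 to compound 4 (0.52 log units; beyond the scatter), still a small fraction of the gap between compound 1 and compound 3. Compound 4 is expected to give about 5 nM in this assay, with a range from 1.5 nM to 20 nM.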

Compound 4, half-maximal effective concentration: 4.47 nM
Beside the measured number, compound 4's estimate is 1.1-fold (0.05 log units) above it, within the range that was stated.
By their numbers in this assay, from the lowest: compound 1; then compound 4; then compound 2; then compound 3.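

Vinyl in place of trifluoromethyl on this aromatic carbon, ortho to a large group, gives a small change in this assay, with a 3.0-fold higher number from compound 1 to compound 4 (0.47 log units; beyond the scatter) as a modest step. Fluorine is therefore not required at this position for an effect at small amounts of compound, though the swap does not leave the number unchanged. Nothing measured on either group bears on the size of this step, so it stays without an explanation.

A single pair cannot show whether the number follows the count of heavy atoms, so a methyl, an ethyl, a nitrile or a methoxy group on the same aromatic carbon remains an open question. From the compounds shown here alone, it also remains open whether vinyl placed elsewhere on the aromatic ring would give a comparable number.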